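Swapping chloro for sulfamoyl on the anilino ring

The source may report more compounds than this note shows. Statements on the series, on what has been measured and on what is new or still open speak of the compounds shown alone.

Of the compounds shown here, three sharing one core have been tested in a functional assay on MOLT-4 cells (Homo sapiens) for antiproliferative activity, read by CCK-8 assay, with a stated time of 72 h; on this read-out higher numbers stand for weaker inhibition and lower numbers for stronger inhibition. Compound 1 `Cc1cc(Nc2cc(N3CCN(C)CC3)nc(Nc3cccc(Cl)c3)n2)n[nH]1` gives 20.1 nM. Compound 2 `Cc1cc(Nc2cc(N3CCN(C)CC3)nc(Nc3ccc(Cl)cc3)n2)n[nH]1` gives 53.1 nM, the highest of the three numbers. Compound 3 `Cc1cc(Nc2cc(N3CCN(C)CC3)nc(Nc3ccc(C#N)cc3)n2)n[nH]1` gives 13.6 nM. Compared with its nearest neighbour, the step reads a 2.6-fold higher number from compound 1 to compound 2 (0.42 log units; beyond the scatter); compared with its furthest, a 3.9-fold lower number from compound 2 to compound 3 (0.59 log units; beyond the scatter).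

Compound 4 `Cc1cc(Nc2cc(N3CCN(C)CC3)nc(Nc3ccc(S(N)(=O)=O)cc3)n2)n[nH]1` is not yet measured. It differs from compound 2 in one place: sulfamoyl in place of chloro on an aromatic carbon. The step that bears most directly on this change is a 3.9-fold lower number from compound 2 to compound 3 (0.59 log units; beyond the scatter), where a cyano replaced the same chloro on the same aromatic carbon, a modest move beyond the scatter. The change from compound 1 to compound 3 stayed within the scatter, a 1.5-fold lower number from compound 1 to compound 3 (0.17 log units; within the scatter). Only one other replacement of that chloro has been measured, so the direction rests on a single example. A modest fall in the number is expected for compound 4, a 2.1-fold lower number from compound 2 to compound 4 (0.33 log units; beyond the scatter). The estimate for compound 4 in this assay is 25 nM, with a range from 8 nM to 80 nM.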

Compound 4, half-maximal inhibitory concentration: 648 nM
Compound 4: middle estimate off by 26-fold (1.41 log units), on the low side; measured number outside the range, above it.
By their numbers in this assay, from the lowest: compounds 3 and 1 (each within the scatter of the next); then compound 2; then compound 4.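

In this assay sulfamoyl in place of chloro gives a 12-fold higher number from compound 2 to compound 4 (1.09 log units; beyond the scatter) and so runs the opposite way to the cyano swap on the same aromatic carbon. Sulfamoyl in place of cyano gives a 48-fold higher number from compound 3 to compound 4 (1.68 log units; beyond the scatter) and 4-sulfamoylphenyl in place of 3-chlorophenyl gives a 32-fold higher number from compound 1 to compound 4 (1.51 log units; beyond the scatter) which leaves compound 4 as the weakest of the four, with all its steps beyond the scatter. This carbon is therefore far from indifferent to what sits on it: a swap here can move the number in either direction, and the single cyano result gave no sign of how far.

On these data alone, whether an amine, a carboxylic acid or a methylsulfonyl group on this carbon would behave more like cyano or more like sulfamoyl stays open. Nothing measured here explains the rise seen with sulfamoyl.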